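The source may report more compounds than this note shows. Statements on the series, on what has been measured and on what is new or still open speak of the compounds shown alone.

Measured compounds:
- Compound 1, `COc1cc(C)nc2n/c(=N/C(=O)c3c(-c4ccc(Cl)cc4Cl)noc3C)sn12`: 80.6%
- Compound 2, `Cc1onc(-c2ccc(Cl)cc2Cl)c1C(=O)/N=c1/nc2nc(Cl)cc(C)n2s1`: 68.1%
- Compound 3, `COc1cc(OC)n2s/c(=N\C(=O)c3c(-c4ccc(Cl)cc4Cl)noc3C)nc2n1`: 85.3%

In a functional assay on the whole organism for inhibition, with Digitaria ciliaris as the target, with a stated time of 72 h, tested at 100 mg/L (on this read-out higher numbers stand for more inhibition of growth at the one concentration tested and lower numbers for less inhibition of growth), compound 1 stands second of the three numbers; its nearest neighbour, compound 3, differs by a step within the scatter, a number 4.7 percentage points higher from compound 1 to compound 3 (within the scatter), while compound 2 lies beyond the scatter below it. Compound 4, `CSc1cc(C)nc2n/c(=N/C(=O)c3c(-c4ccc(Cl)cc4Cl)noc3C)sn12`, differs from compound 1 by methylsulfanyl in place of methoxy on an aromatic carbon. Among the measured compounds shown here, no measured step swaps these two groups; the only measured step at this site, a number 4.7 percentage points higher from compound 1 to compound 3 (within the scatter), was within the scatter, so a change at this carbon has so far left the read-out largely unmoved. The expectation is therefore a step of a number 2.6 percentage points lower from compound 1 to compound 4 (within the scatter), no more than the scatter, in either direction. Compound 4 is estimated at 78%, between 60% and 92%.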

Compound 4, percent growth inhibition at one concentration: 70.6%
For compound 4 the middle estimate is 7.4 percentage points above the measured one; low and high end bracket the measured number.
By their numbers in this assay, from the lowest: compounds 2, 4, 1 and 3 (each within the scatter of the next, the first and the last beyond it).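

In this assay, putting methylsulfanyl in place of methoxy gives a number 10 percentage points lower from compound 1 to compound 4 (within the scatter). Among the compounds shown here, this is the first measured change of the methoxy group itself, and it shows that this carbon, next to the ring nitrogen, can carry a sulfur-linked group in place of an oxygen-linked one without a step beyond the scatter. No available evidence accounts for the size of this step.

As far as these compounds go, how an amine or a longer chain, such as ethoxy, would fare on this carbon remains open. With a single step, no trend can be drawn for this position.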